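Title: Removing a phosphate from the methoxy nucleotide of compound 3

The compounds below may be only part of what the source reports. "The series", "measured", "known", "first", "only" and "open" are said of these compounds alone.

Measured so far:
Compound 1, `CNc1nc(=O)ccn1[C@@H]1O[C@H](COP(=O)(O)O)[C@@H](O)[C@H]1O`, in an in vitro functional assay on 1321-N1 cells for agonist activity at P2Y purinoceptor 2 (Homo sapiens), read by scintillation proximity assay and inositol phosphate accumulation (a lower number here means that less compound is needed, a higher number that more compound is needed for the effect), gives > 100000 nM, a limit of the assay rather than a number.
Compound 2, `O=c1ccn([C@@H]2O[C@H](COP(=O)(O)O)[C@@H](O)[C@H]2O)c(SCCc2ccccc2)n1`, gives 1300 nM.
Compound 3, `COc1nc(=O)ccn1[C@@H]1O[C@H](COP(=O)(O)OP(=O)(O)O)[C@@H](O)[C@H]1O`, gives 907 nM.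

Compound 3 holds the lowest of the two numbers shown; its nearest neighbour is compound 2, and the gap between them lies within the scatter, so no order between these two can be read. The one limit shown is that of compound 1 (the limit of > 100000 nM in this assay, at which 1 of the 3 values shown sits).

Compound 4, `COc1nc(=O)ccn1[C@@H]1O[C@H](COP(=O)(O)O)[C@@H](O)[C@H]1O`, differs from compound 3 by a hydrogen atom in place of a group of 4 heavy atoms (3 oxygen, 1 phosphorus; no ring), on an oxygen, that is, a hydrogen atom in place of a group of 4 heavy atoms on an oxygen whose other neighbour is phosphorus. Among the measured compounds shown here, the only measured step, an at least 76-fold lower number from compound 1 to compound 2 (1.88 log units; beyond the scatter), concerns a change on the aromatic carbon and not the phosphate chain, so it does not bear on this step directly. For the measured compounds named here, it shows only that a compound carrying a single phosphate, compound 2, can still register a number, while compound 1 with the same chain does not. The effect of shortening the chain itself remains unmeasured. From compound 3 to compound 4 the account expects a step toward a higher number, an 11-fold higher number from compound 3 to compound 4 (1.04 log units; beyond the scatter), with a real chance that only a limit is reported. Compound 4 is therefore estimated at 10000 nM, between 1500 nM and 100000 nM.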

Compound 4, half-maximal effective concentration: 9900 nM
Compound 4: the middle estimate sits 1.0-fold (0.00 log units) above what was measured; the measured number falls inside the stated range.
By their numbers in this assay, from the lowest: compounds 3 and 2 (each within the scatter of the next); then compound 4. At a limit, above all of these: compound 1.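

In this assay, among the compounds shown here, the phosphate chain proves to matter on its own: loss of the group of 4 heavy atoms from the oxygen whose other neighbour is phosphorus gives an 11-fold higher number from compound 3 to compound 4 (1.04 log units; beyond the scatter) and is the first change to the chain that can be read. With the single phosphate held constant, the group on the aromatic carbon also separates the compounds, giving a 7.6-fold higher number from compound 2 to compound 4 (0.88 log units; beyond the scatter) for methoxy in place of phenethylsulfanyl and an at least 10-fold lower number from compound 1 to compound 4 (1.00 log units; beyond the scatter) for methoxy in place of methylamino. The last of these steps rests on a limit for compound 1, not a number: the limit of > 100000 nM in this assay, at which 1 of the 4 values shown sits.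

On these data alone, whether the chain has the same weight with phenethylsulfanyl or methylamino on the aromatic carbon remains open. So does what a longer chain, a triphosphate, would do with methoxy, or how ethoxy would compare on that carbon.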